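Methoxy to ethyl: notes on one substituent swap

A few compounds are considered here, and "the series" means these few. Any claim that something is new, unique, unknown or untested is made for them only; others in the source may bear on it.

Of the compounds shown here, two have been measured so far in a functional assay on HCT-116 cells (Homo sapiens) for inhibition, read by CCK-8 assay, with a stated time of 72 h, tested at 2 uM; on this read-out higher numbers stand for more inhibition of growth at the one concentration tested and lower numbers for less inhibition of growth. Compound 1 (`Nc1ccccc1NC(=O)/C=C/c1ccc(CSc2ccc(Cl)cc2)cc1`) gives 5.62%. Compound 2 (`COc1ccc(SCc2ccc(C(=O)Nc3ccccc3N)cc2)cc1`) gives 73.3%, the higher of the two numbers, and the gap to compound 1 lies beyond the scatter. These two compounds differ in more than one place, so their gap cannot be assigned to any single group.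

Compound 3 (`CCc1ccc(SCc2ccc(C(=O)Nc3ccccc3N)cc2)cc1`) departs from compound 2 in one place: ethyl in place of methoxy on an aromatic carbon. The methoxy group of compound 2 gives way to an ethyl group, and the rest of the structure stays the same. Going by the values given here, no measured pair isolates this change, so the expectation rests on compound 2 alone, at 73.3%. A slight loss in this assay is expected, not beyond the scatter, and the estimated change is a number 6.3 percentage points lower from compound 2 to compound 3 (within the scatter). Compound 3 is estimated at 67%, with an expected range from 48% to 83%.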

Compound 3, percent growth inhibition at one concentration: 40.7%
The estimate for compound 3 lay 26.3 percentage points above the measured number, outside the stated range (below it).
By their numbers in this assay, from the lowest: compound 1; then compound 3; then compound 2.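

In this assay, ethyl in place of methoxy gives a number 32.6 percentage points lower from compound 2 to compound 3 (beyond the scatter), so this position, para to a large group, responds strongly to a swap that keeps the count at 2 heavy atoms. The swap replaces a carbon and its hydrogen-bond acceptor count of 1 with a group counted at 0, and this one pair ties the drop to the change from 4-methoxyphenyl to 4-ethylphenyl on an otherwise unchanged structure. Nothing available here explains the size of this step.

The compounds shown leave open whether the oxygen of the methoxy group or some other difference between the two groups accounts for the step. Ethoxy, hydroxyl or an amine at the same place would test this, and whether the step carries over to other parts of the series also remains open.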